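This account rests on a few compounds, and the source may have more. Where it says the series, first, only, none or still open, it means among the compounds named here.

Measured compounds:
Compound 1 `C[C@H](Nc1ncnc2[nH]cnc12)c1nn(-c2cccnc2)c2cc(Cl)ccc12` — in a functional assay on Bel-7402 cells (Homo sapiens) for inhibition, read by sulforhodamine B assay, with a stated time of 72 h, tested at 10 uM (on this read-out higher numbers stand for more inhibition at the one concentration tested (going by the name of the read-out) and lower numbers for less inhibition), compound 1 gives 17%.
Compound 2 `C[C@H](Nc1nc(N)nc2[nH]cnc12)c1nn(-c2cccnc2)c2cc(F)ccc12` — in this assay compound 2 gives -5%.
Compound 3 `C[C@H](Nc1ncnc2[nH]cnc12)c1nn(-c2ccc(C#N)cc2)c2cc(F)ccc12` — in this assay compound 3 gives 0%.

Among these three numbers compound 3 stands second highest. Its nearest neighbour is compound 2, whose value lies lower by an amount that falls within the usual scatter of this measurement, so the two cannot be told apart. The furthest is compound 1, whose value lies higher by an amount beyond the scatter; compound 1 and compound 3 differ from each other in more than one place, so only the two values themselves can be compared, and no single change can be held responsible.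

Compound 4 `C[C@H](Nc1ncnc2[nH]cnc12)c1nn(-c2ccncc2)c2cc(F)ccc12` has not yet been measured. It differs from compound 3 in one place: pyridin-4-yl in place of 4-cyanophenyl on an aromatic nitrogen. The change is small in size, a pyridin-4-yl in place of a 4-cyanophenyl on the aromatic nitrogen. No measured pair in this set isolates such a change, so there is no shown step to lean on. With compound 2 and compound 3 both sitting near the bottom of the range, compound 4 is expected to stay close to compound 3, with a step of a number 5 percentage points higher from compound 3 to compound 4 (within the scatter) that is expected to fall within the scatter rather than beyond it. The estimate for compound 4 in this assay is 5%, expected to lie between -10% and 20%.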

Compound 4, a percentage reported as inhibition, at one concentration (the size of the read-out at that concentration, not a potency): 16%
Estimate against measurement, compound 4: 11 percentage points below, within the range that was stated.
By their numbers in this assay, from the lowest: compounds 2 and 3 (each within the scatter of the next); then compounds 4 and 1 (each within the scatter of the next).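

In this assay, among the compounds shown here, replacing 4-cyanophenyl with pyridin-4-yl on the aromatic nitrogen gives a number 16 percentage points higher from compound 3 to compound 4 (beyond the scatter), the only single change in this set that can be read, and it shows that the read-out responds to the group at this position. The earlier compounds shown here could not show this, since they differ from each other in more than one place and offered only separate values. The size of the effect remains limited, as compound 4 gives 16% at the one concentration tested, and nothing available here accounts for the step, which therefore stands as an observation about this one pair.

From the compounds shown here alone, the step comes from one pair with one core, so whether the same exchange would produce a similar step alongside the chloro substituent of compound 1 or the additional amine of compound 2 remains open. Also open, going by these compounds, is how the read-out would respond to other groups on this aromatic nitrogen, such as a phenyl ring bearing a carboxylic acid, a pyridin-2-yl ring or a longer alkyl chain.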